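Spiro-diamine in place of methylpyrrolidine on a quinoline core

The source may hold more compounds than are shown below. What is called first, only, known or untested is meant among the compounds shown, and "the series" means these compounds.

Measured compounds and their results:
Compound 1, `CN(c1ccc2cc(NC(=O)CCc3ccc(C(F)(F)F)cc3)ccc2n1)C1CCCCC1`, in an assay on isolated protein for displacement of a labelled ligand from melanin-concentrating hormone receptor 1 (Homo sapiens) (a lower number here means a stronger inhibitor, a higher number a weaker inhibitor), compound 1 gives 18 nM.
Compound 2, `CC1CCCN1c1ccc2cc(NC(=O)CCc3ccc(C(F)(F)F)cc3)ccc2n1`, in this assay compound 2 gives 5 nM.
Compound 3, `CC1CCN(c2ccc3cc(NC(=O)CCc4ccc(C(F)(F)F)cc4)ccc3n2)C1`, in this assay compound 3 gives 2 nM.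

Compound 3 has the lowest number of the three: a 2.5-fold lower number from compound 2 to compound 3 (0.40 log units; beyond the scatter) and a 9.0-fold lower number from compound 1 to compound 3 (0.95 log units; beyond the scatter), both beyond the scatter, so it is the strongest of the measured set.

Compound 4, `O=C(CCc1ccc(C(F)(F)F)cc1)Nc1ccc2nc(N3CCC4(CCNC4)C3)ccc2c1`, has not yet been measured. It differs from compound 3 in one place: a group of 9 heavy atoms (7 carbon, 2 nitrogen; 2 five-membered non-aromatic rings with 1 hetero atom each) in place of a group of 6 heavy atoms (5 carbon, 1 nitrogen; one five-membered non-aromatic ring with 1 hetero atom), on an aromatic carbon. The new group keeps a five-membered ring on the aromatic carbon but adds a second ring bearing a hydrogen-bond donor.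

All three measured steps change the amine at this same position, and each was modest: a 3.6-fold lower number from compound 1 to compound 2 (0.56 log units; beyond the scatter), a 9.0-fold lower number from compound 1 to compound 3 (0.95 log units; beyond the scatter), a 2.5-fold lower number from compound 2 to compound 3 (0.40 log units; beyond the scatter). Within the data shown here, none of them adds a second ring or a donor, so they show only that this position tolerates changes of shape without large swings. A modest step in either direction is therefore expected for compound 4, most likely close to compound 3, a 2.0-fold higher number from compound 3 to compound 4 (0.30 log units; within the scatter). Compound 4 is expected to give about 4 nM, within a range from 1 nM to 25 nM.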

Compound 4, half-maximal inhibitory concentration: 0.5 nM
Compound 4: middle estimate off by 8.0-fold (0.90 log units), on the high side; measured number below the stated range.
By their numbers in this assay, from the lowest: compound 4; then compound 3; then compound 2; then compound 1.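

In this assay, the change at this position, on an aromatic carbon next to the ring nitrogen, brings in a second ring and a hydrogen-bond donor together, and the number falls further (a 4.0-fold lower number from compound 3 to compound 4 (0.60 log units; beyond the scatter)). Among these compounds, that makes compound 4 the strongest of the four, since the gaps to the other two compounds are wider still (a 10-fold lower number from compound 2 to compound 4 (1.00 log units; beyond the scatter); a 36-fold lower number from compound 1 to compound 4 (1.56 log units; beyond the scatter)), and the last of these is the only large step in the set. Group size alone does not set the order: the group of 9 heavy atoms gives the lowest number, whereas the smaller cyclohexyl(methyl)amino group in compound 1 gives the highest, so this position accepts a larger group when it has the right shape or make-up.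

From the compounds shown here alone, the second ring and the donor arrive as one change, so their separate shares stay open; a piperazine ring, or a methyl group on the nitrogen of the second ring, would begin to pull them apart. No available evidence explains why this change lowers the number.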